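Working notes: replacing 2-chlorophenyl with 4-nitrophenyl

The source may hold more compounds than are shown below. What is called first, only, known or untested is meant among the compounds shown, and "the series" means these compounds.

In a functional assay on HeLa cells (Homo sapiens) for antiproliferative activity, read by MTT assay, with a stated time of 72 h (a higher number here means a weaker inhibitor, a lower number a stronger inhibitor), compound 1 `Nc1nc(N)c2cc(CSC(=S)N3CCN(C4CCCCC4)CC3)ccc2n1` gives 5960 nM while compound 2 `Cc1ccc(N2CCN(C(=S)SCc3ccc4nc(N)nc(N)c4c3)CC2)cc1` gives 2130 nM and compound 3 `Nc1nc(N)c2cc(CSC(=S)N3CCN(c4ccccc4Cl)CC3)ccc2n1` gives 4050 nM on the same read-out. Compound 3 stands within the scatter of both others, with a 1.5-fold lower number from compound 1 to compound 3 (0.17 log units; within the scatter) and a 1.9-fold higher number from compound 2 to compound 3 (0.28 log units; within the scatter) as its two steps. Only a 2.8-fold lower number from compound 1 to compound 2 (0.45 log units; beyond the scatter) passes beyond the scatter, and it is a modest step.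

Compound 4 `Nc1nc(N)c2cc(CSC(=S)N3CCN(c4ccc([N+](=O)[O-])cc4)CC3)ccc2n1` differs from compound 3 at one place: 4-nitrophenyl in place of 2-chlorophenyl on an amine nitrogen in a ring is the whole change, 4-nitrophenyl in place of 2-chlorophenyl on an amine nitrogen in a ring. All three measured steps alter the group at this same place, but none brings in 4-nitrophenyl, so the data do not show what this group does. For the measured compounds named here, the nearest precedent, one substituted phenyl for another, is a 1.9-fold higher number from compound 2 to compound 3 (0.28 log units; within the scatter) and stays within the scatter. No step beyond the scatter is therefore expected in this assay and no direction can be called, although a modest step like a 2.8-fold lower number from compound 1 to compound 2 (0.45 log units; beyond the scatter) remains possible. The estimated step is a 1.1-fold lower number from compound 3 to compound 4 (0.05 log units; within the scatter) and would lie within the scatter. Compound 4 is estimated at 3600 nM with an expected range of 1600 nM to 8000 nM for now.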

Compound 4, half-maximal inhibitory concentration: 1660 nM
Compound 4: the middle estimate sits 2.2-fold (0.34 log units) above what was measured, within the range that was stated.
By their numbers in this assay, from the lowest: compounds 4, 2, 3 and 1 (each within the scatter of the next, the first and the last beyond it).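

In this assay, a swap of one substituted phenyl for another on the amine nitrogen now gives a step beyond the scatter (a 2.4-fold lower number from compound 3 to compound 4 (0.39 log units; beyond the scatter)), which the earlier phenyl pair did not show (a 1.9-fold higher number from compound 2 to compound 3 (0.28 log units; within the scatter)). Nitro in place of methyl on an aromatic carbon gives no readable difference (a 1.3-fold lower number from compound 2 to compound 4 (0.11 log units; within the scatter)), so 4-nitrophenyl and 4-methylphenyl cannot be told apart here, although they differ in the atoms they carry and in their hydrogen-bond acceptor count. Against cyclohexyl, 4-nitrophenyl gives the largest step in the set (a 3.6-fold lower number from compound 1 to compound 4 (0.56 log units; beyond the scatter)), which is still modest, and nothing available bears on the reason for any of these differences.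

From the compounds shown here alone, it remains open whether the gap to compound 3 follows the identity of the substituent or its place on the phenyl ring, a question that a 4-chlorophenyl group on the same nitrogen would address. Also open, going by these compounds, is whether an amine or a carboxylic acid in place of nitro on that aromatic carbon would stay level with compound 2 and compound 4 or fall outside the scatter around them.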